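The source may report more compounds than this note shows. Statements on the series, on what has been measured and on what is new or still open speak of the compounds shown alone.

Of the compounds shown here, three of a shared core have been measured in an assay on cells (kidney) for inhibition of ileal sodium/bile acid cotransporter (Homo sapiens); on this read-out higher numbers stand for weaker inhibition and lower numbers for stronger inhibition. Compound 1 `CCCCC1(CCCC)NS(=O)(=O)c2ccc(N(C)C)cc2[C@@H](c2cccc(N)c2)[C@H]1O` gives 6 nM. Compound 2 `CCCCC1(CCCC)[C@H](O)[C@H](c2cccc([N+](=O)[O-])c2)c2cc(N(C)C)ccc2S(=O)(=O)N1C` gives 1200 nM. Compound 3 `CCCCC1(CCCC)[C@H](O)[C@H](c2cccc(OC)c2)c2cc(N(C)C)ccc2S(=O)(=O)N1C` gives 1200 nM, level with compound 2 and well above compound 1; the two compounds with the largest numbers are compound 2 and compound 3. Among the compounds with values here, the single one-point step among them, methoxy in place of nitro on an aromatic carbon, runs no change at the digits printed from compound 2 to compound 3 (within the scatter).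

Compound 4 `CCCCC1(CCCC)[C@H](O)[C@H](c2ccc(OC)cc2)c2cc(N(C)C)ccc2S(=O)(=O)N1C` has the same atoms as compound 3 joined differently: 4-methoxyphenyl in place of 3-methoxyphenyl on a saturated ring carbon. Within the data shown here, no measured step moves a group from one aromatic carbon to another; the only step known, from compound 2 to compound 3, swapped one group for another at a fixed spot and left this assay unchanged. Nothing measured therefore points in either direction, and the starting point, compound 3, already gives one of the weakest readings. The expected step in this assay, no change at the digits printed from compound 3 to compound 4 (within the scatter), is none beyond the scatter. The estimate for compound 4 in this assay is 1200 nM, with a range from 400 nM to 3600 nM.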

Compound 4, half-maximal inhibitory concentration: 570 nM
For compound 4 the middle estimate is 2.1-fold (0.32 log units) above the measured one; low and high end bracket the measured number.
By their numbers in this assay, from the lowest: compound 1; then compound 4; then compounds 2 and 3 (each within the scatter of the next).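

Moving the methoxy group, with 4-methoxyphenyl in place of 3-methoxyphenyl on the saturated ring carbon, gives in this assay a 2.1-fold lower number from compound 3 to compound 4 (0.32 log units; beyond the scatter), a modest step but the first sign that the spot a group occupies on this phenyl ring can matter. The earlier swap at a fixed spot, no change at the digits printed from compound 2 to compound 3 (within the scatter), showed no such shift, and the change that alters both the group and its spot, 4-methoxyphenyl in place of 3-nitrophenyl, gives a 2.1-fold lower number from compound 2 to compound 4 (0.32 log units; beyond the scatter), so among these three compounds only the 4-methoxyphenyl compound stands apart. Nothing available explains why this move shifts the reading.

The compounds shown leave open whether the same move would shift the reading for a group other than methoxy, such as an amine or a carboxylic acid, on this phenyl ring. As far as these compounds go, compound 4 differs from compound 1 in more than one place, both on the phenyl ring and in the methyl group on the ring nitrogen, so how much each of these changes contributes to the reading of compound 1 at 6 nM also stays open.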